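Acetylation of the ring amine in the amide series

The source may report more compounds than this note shows. Statements on the series, on what has been measured and on what is new or still open speak of the compounds shown alone.

Compound 1 `Cc1ccc(C(=O)Nc2cccc(-c3ccnc4c(N)cccc34)c2)cc1C` carries a 3,4-dimethylphenyl amide on the shared core. In a functional assay on A375P cells (Homo sapiens) for antiproliferative activity, read by MTT assay, with a stated time of 48 h (a higher number here means a weaker inhibitor, a lower number a stronger inhibitor), compound 1 gives > 20000 nM, which is a limit of the assay and not a number. Compound 2 `Nc1cccc2c(-c3cccc(NC(=O)c4nccs4)c3)ccnc12` has the same core and gives 16700 nM in this assay. Compound 3 `Nc1cccc2c(-c3cccc(NC(=O)c4cc5ccccc5s4)c3)ccnc12` likewise gives only a limit, > 20000 nM, in this assay. The measured steps all move the aryl group on the carbonyl carbon: an at least 1.1-fold lower number from compound 1 to compound 2 (0.07 log units; that floor lies within the scatter), an at least 1.1-fold higher number from compound 2 to compound 3 (0.07 log units; that floor lies within the scatter), and a step that the two limits leave unreadable from compound 1 to compound 3. Among the measured compounds shown here, none of them reads beyond the scatter, and the limit of > 20000 nM in this assay, at which 2 of the 3 values shown sit, holds two of the three values, so the series so far is flat at the top of the assay window.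

Compound 4 `CC(=O)Nc1cccc2c(-c3cccc(NC(=O)c4ccc(C)c(C)c4)c3)ccnc12` differs from compound 1 only at the ring nitrogen: acetyl in place of hydrogen on a nitrogen on an aromatic ring. No measured step touches this position; the three steps shown all concern the amide aryl group and none gives a basis for a direction here. Since compound 1 sits at the limit > 20000 nM, the expectation for compound 4 is that it also lands at or near the limit, with a number no higher from compound 1 to compound 4 (the limit leaves the size open) estimated as no step beyond the scatter. Compound 4 is therefore expected to give about 20000 nM in this assay, within 8000 nM to 60000 nM.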

Compound 4, half-maximal inhibitory concentration: > 20000 nM
Compound 4 gave a limit, no number; the forecaster's own chance of this, stated with the estimate: 60%; the middle value sits exactly at the limit.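

No new step can be read: compound 1 and compound 4 each give only a limit in this assay, and the series stays at that ceiling: the limit of > 20000 nM in this assay, at which 3 of the 4 values shown sit.

The compounds shown leave open whether acetyl in place of hydrogen on a nitrogen on an aromatic ring changes the read-out at all, and in which direction.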